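The compounds below may be only part of what the source reports. "The series", "measured", "known", "first", "only" and "open" are said of these compounds alone.

In a functional assay on MOLT-4 cells (Homo sapiens) for antiproliferative activity, read by MTT assay, with a stated time of 3 days (on this read-out higher numbers stand for weaker inhibition and lower numbers for stronger inhibition), compound 3 `CCCCCc1ccc(C#Cc2cn(C/C=C/CN3C(=O)c4ccccc4C3=O)c(=O)[nH]c2=O)cc1` gives 17000 nM. Its double-bond isomer, compound 1 `CCCCCc1ccc(C#Cc2cn(C/C=C\CN3C(=O)c4ccccc4C3=O)c(=O)[nH]c2=O)cc1`, gives 30000 nM, and a 1.8-fold lower number from compound 1 to compound 3 (0.25 log units; within the scatter) leaves the two level, so compound 3 stands with compound 1 at the active end of the numbers shown. Compound 2 `CCCCCC#Cc1cn(C/C=C/CN2C(=O)c3ccccc3C2=O)c(=O)[nH]c1=O` gives > 500000 nM, which is a limit of this assay and not a number.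

The next change leads to compound 4 `O=C1c2ccccc2C(=O)N1C/C=C/Cn1cc(C#CCCc2ccccc2)c(=O)[nH]c1=O`: phenethyl in place of 4-pentylphenyl on a triple-bonded carbon. The measured step that bears on it is an at least 29-fold lower number from compound 2 to compound 3 (1.46 log units; beyond the scatter), seen with 4-pentylphenyl in place of pentyl on a triple-bonded carbon. The double-bond step concerns another part of the structure and carries no weight here. Phenethyl differs from both groups in that comparison, so only part of the large step is expected to return, as a higher number beyond the scatter. The estimated step is a 7.1-fold higher number from compound 3 to compound 4 (0.85 log units; beyond the scatter). For compound 4 the expected value is 120000 nM, with an estimated range of 35000 nM to 400000 nM.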

Compound 4, half-maximal inhibitory concentration: 39000 nM
Estimate against measurement, compound 4: 3.1-fold (0.49 log units) above; the measured number falls inside the stated range.
By their numbers in this assay, from the lowest: compounds 3, 1 and 4 (each within the scatter of the next, the first and the last beyond it). At a limit, above all of these: compound 2.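

Compound 2 stays at > 500000 nM in this assay, which is a limit and not a number. A phenyl ring carried on a saturated chain also gives a readable value, with an at least 12-fold lower number from compound 2 to compound 4 (1.10 log units; beyond the scatter), so the gain over the straight chain does not need 4-pentylphenyl itself on the triple-bonded carbon, while the exchange of 4-pentylphenyl for phenethyl is a modest one, with a 2.3-fold higher number from compound 3 to compound 4 (0.36 log units; beyond the scatter). Nothing measured here accounts for either step.

The compounds shown leave open whether the ring itself or the overall size of the group carries the gain over pentyl. An amine or a carboxylic acid on the phenyl ring of phenethyl, or a longer chain in its place, would be needed to show how far this position tolerates change.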